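Glycine transporter 1 series: ring change on the amide nitrogen

The compounds below may be only part of what the source reports. "The series", "measured", "known", "first", "only" and "open" are said of these compounds alone.

Measured compounds:
- Compound 1, `O=C(CN(C(=O)c1ccccc1Cl)C1CCCCC1)Nc1cc(F)cc(F)c1`, in an assay on HEK293 cells for inhibition of sodium- and chloride-dependent glycine transporter 1 (Homo sapiens), read by scintillation proximity assay (on this read-out higher numbers stand for weaker inhibition and lower numbers for stronger inhibition), compound 1 gives 20000 nM.
- Compound 2, `O=C(CN(C(=O)c1ccc(-c2ccccn2)cc1)C1CCCCC1)Nc1cc(F)cc(F)c1`, in this assay compound 2 gives 63.1 nM.
- Compound 3, `O=C(CN(CC1CC1)C(=O)c1ccc(-c2ccccn2)cc1)Nc1cc(F)cc(F)c1`, in this assay compound 3 gives 200 nM.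

Compound 3 holds the second highest of the three numbers. Among the measured compounds shown here, its nearest neighbour is compound 2, and the only single-change step in this set runs between them: a 3.2-fold higher number from compound 2 to compound 3 (0.50 log units; beyond the scatter). Compound 1, which carries a different aryl group on the carbonyl, sits far above both.

Compound 4, `O=C(CN(C(=O)c1ccc(-c2ccccn2)cc1)C1CCCOC1)Nc1cc(F)cc(F)c1`, differs from compound 3 in one place: oxan-3-yl in place of cyclopropylmethyl on an amide-type nitrogen. For the measured compounds named here, the one step that bears on it, a 3.2-fold higher number from compound 2 to compound 3 (0.50 log units; beyond the scatter), shows that the six-membered carbon ring on this nitrogen gave a lower number than cyclopropylmethyl. Going by the values given here, the entering oxan-3-yl is again a six-membered non-aromatic ring, now with one oxygen, so a move back toward the number of compound 2 is expected, though no measured pair shows what the ring oxygen itself contributes.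

For compound 4 the expected step in this assay is a 2.0-fold lower number from compound 3 to compound 4 (0.30 log units; within the scatter), a modest lowering. The estimate for compound 4 is 100 nM, with a range from 40 nM to 300 nM.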

Compound 4, half-maximal inhibitory concentration: 79.4 nM
Estimate against measurement, compound 4: 1.3-fold (0.10 log units) above; measured number inside the range.
By their numbers in this assay, from the lowest: compounds 2 and 4 (each within the scatter of the next); then compound 3; then compound 1.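

In this assay, oxan-3-yl on the amide-type nitrogen gives a 2.5-fold lower number from compound 3 to compound 4 (0.40 log units; beyond the scatter), so a second six-membered non-aromatic ring, this one with an oxygen, also falls on the lower side of cyclopropylmethyl. The comparison with the carbon ring is new: a 1.3-fold higher number from compound 2 to compound 4 (0.10 log units; within the scatter), so at this position, with the aryl group of compound 2 held constant, a ring oxygen in place of a ring carbon gives no change that can be told from the scatter. No measurement on hand explains either step.

As far as these compounds go, compound 2, compound 3 and compound 4 do not separate ring size from ring type, so it remains open whether a smaller ring directly on this nitrogen, or an open methoxyethyl chain, would fall with cyclopropylmethyl or with the six-membered rings. Also open, from the compounds shown here alone, are how a basic ring amine such as piperidinyl would fare at this position, and whether oxan-3-yl would behave the same way with the different aryl group of compound 1.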